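Trifluoromethyl to Methoxy: an Expected Loss of Cell-Growth Inhibition

A few compounds are considered here, and "the series" means these few. Any claim that something is new, unique, unknown or untested is made for them only; others in the source may bear on it.

The account compares two measured esters and one not yet tested. Compound 1, `Cc1cc2c(C(C)C)ccc(C)c2cc1OC(=O)c1ccc(C(F)(F)F)cc1`, stands highest of the two numbers in hand: in a functional assay on PC-3 cells (Homo sapiens) for antiproliferative activity, read by sulforhodamine B assay, with a stated time of 48 h, tested at 50 uM (on this read-out higher numbers stand for more inhibition at the one concentration tested (going by the name of the read-out) and lower numbers for less inhibition), compound 1 gives 100%. Compound 2, `CC1=CC[C@H](C(C)C)c2cc(C)c(OC(=O)c3ccc(Cl)cc3)cc21`, differs from compound 1 in more than one place; in this assay compound 2 gives 34.1%, a reading far below that of compound 1, though the two values alone cannot say which of the several differences carries the drop.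

Compound 3, `COc1ccc(C(=O)Oc2cc3c(C)ccc(C(C)C)c3cc2C)cc1`, is the unmeasured member. It differs from compound 1 in a single place: methoxy in place of trifluoromethyl on an aromatic carbon. Within the data shown here, no measured pair isolates this kind of change, so the expectation leans on where compound 1 sits. Because compound 1 already reaches 100%, no higher reading is possible, and a downward step is expected, a number 30 percentage points lower from compound 1 to compound 3 (beyond the scatter), likely beyond the scatter but shallower than the fall seen with compound 2. Compound 3 is therefore estimated at 70%, within a range from 35% to 100%.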

Compound 3, a percentage reported as inhibition, at one concentration (the size of the read-out at that concentration, not a potency): 10.4%
The estimate for compound 3 lay 59.6 percentage points above the measured number; measured number outside the range, below it.
By their numbers in this assay, from the lowest: compound 3; then compound 2; then compound 1.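

Trifluoromethyl and methoxy sit on an aromatic carbon of a six-membered aromatic ring of carbon only, para to a large group, and in this assay exchanging the first for the second gives a number 89.6 percentage points lower from compound 1 to compound 3 (beyond the scatter). Among these compounds, the earlier compounds differed in more than one place, so this is the first reading that ties a change in inhibition to this one position: with the rest of the structure held constant, the group on this carbon alone separates a high reading from a low one. Nothing measured here explains the step, and the account offers no cause for it.

What the compounds shown leave open is how other groups would read on this same carbon, for instance a nitrile or an amine, and whether either would fall nearer to compound 1 or to compound 3. Also open, going by these compounds, is whether exchanging trifluoromethyl for methoxy would have a step of similar size on the core of compound 2, and how the step at this single concentration would translate into a difference in potency.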